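The source may report more compounds than this note shows. Statements on the series, on what has been measured and on what is new or still open speak of the compounds shown alone.

Working notes on the series, read in a physicochemical assay for solubility, measured as kinetic solubility; a higher number here means a more soluble compound, a lower number a less soluble compound. Compound 1 `O=C(Nc1ccnnc1)c1cc(C(F)(F)F)ccc1OCc1ccccc1` gives < 1000 nM, which is a limit of the assay and not a number. Compound 2 `O=C(Nc1ccnnc1)c1cc(N2CCCCC2)ccc1OCc1ccccc1` gives 60000 nM. Compound 3 `CN1CCC(c2ccc(OCc3ccccc3)c(C(=O)Nc3ccnnc3)c2)CC1` gives 71000 nM, level with compound 2 within the scatter, a 1.2-fold higher number from compound 2 to compound 3 (0.07 log units; within the scatter). Compound 4 `O=C(Nc1ccnnc1)c1cc(N2CCCC2)ccc1OCc1ccccc1` carries pyrrolidin-1-yl in place of 1-methylpiperidin-4-yl on an aromatic carbon, para to a benzyloxy group (pyrrolidin-1-yl in place of 1-methylpiperidin-4-yl on an aromatic carbon). The large steps, an at least 60-fold higher number from compound 1 to compound 2 (1.77 log units; beyond the scatter) and an at least 71-fold higher number from compound 1 to compound 3 (1.85 log units; beyond the scatter), both start from trifluoromethyl, which is absent from compound 3 and compound 4. Within the data shown here, the exchange between the two saturated rings, a 1.2-fold higher number from compound 2 to compound 3 (0.07 log units; within the scatter), is the closest precedent. In this assay no change beyond the scatter is therefore expected, with an estimated step of a 1.2-fold lower number from compound 3 to compound 4 (0.07 log units; within the scatter). For compound 4 the estimated value is 60000 nM, with an expected range of 30000 nM to 110000 nM.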

Compound 4, solubility: 35000 nM
The estimate for compound 4 lay 1.7-fold (0.23 log units) above the measured number; the measured number falls inside the stated range.
By their numbers in this assay, from the lowest: compounds 4, 2 and 3 (each within the scatter of the next, the first and the last beyond it). At a limit, below all of these: compound 1.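

In this assay, among these compounds, contracting the ring to pyrrolidin-1-yl at this position, para to a benzyloxy group, gives the first ring exchange to reach beyond the scatter, though only modestly, with a 2.0-fold lower number from compound 3 to compound 4 (0.31 log units; beyond the scatter), while against piperidin-1-yl it gives a 1.7-fold lower number from compound 2 to compound 4 (0.23 log units; within the scatter). The smaller ring still stands far clear of trifluoromethyl, with an at least 35-fold higher number from compound 1 to compound 4 (1.54 log units; beyond the scatter). Compound 1 is a limit and not a number, so the true size of that step stays unknown: the limit of < 1000 nM in this assay, at which 1 of the 4 values shown sits.

Open, from the compounds shown here alone, is how an open-chain amine such as dimethylamino, or a ring with a second nitrogen such as piperazin-1-yl, would read at this position.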